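Cytotoxicity notes on a labdane-lactone series with quinolinyl ethers

This account rests on a few compounds, and the source may have more. Where it says the series, first, only, none or still open, it means among the compounds named here.

Measured compounds and values in an ADME assay on Vero cells (Chlorocebus sabaeus) for cytotoxicity, read by MTT assay, with a stated time of 48 h; on this read-out higher numbers stand for lower toxicity in this test and lower numbers for higher toxicity in this test:
compound 1 `C=C1CC[C@@H]2[C@](C)(COC(C)=O)[C@H](O)CC[C@@]2(C)[C@@H]1C/C=C1/C(=O)OC[C@@H]1Oc1cccc2cccnc12`: 27500 nM
compound 2 `C=C1CC[C@@H]2[C@](C)(COC(C)=O)[C@H](O)CC[C@@]2(C)[C@@H]1C/C=C1/C(=O)OC[C@H]1Oc1cccc2ccc(C)nc12`: 50600 nM
compound 3 `C=C1CC[C@@H]2[C@](C)(CO)[C@H](O)CC[C@@]2(C)[C@@H]1C/C=C1/C(=O)OC[C@@H]1Oc1cccc2cccnc12`: 20800 nM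

Compound 1 and compound 3 share a core; the difference between them is hydrogen in place of acetyl on an oxygen on a saturated carbon. In this assay this gives a 1.3-fold lower number from compound 1 to compound 3 (0.12 log units; within the scatter), so the two numbers sit within the scatter of each other and no direction can be read from them.

Compound 2 carries a different core, and the difference between the core of compound 2 and the core of compound 1 is not broken down here. In this assay compound 2 gives the highest of the three numbers; its gap to compound 1 lies within the scatter, its gap to compound 3 lies beyond it.

Compound 4 `C=C1CC[C@@H]2[C@](C)(CO)[C@H](O)CC[C@@]2(C)[C@@H]1C/C=C1/C(=O)OC[C@H]1Oc1cccc2ccc(C)nc12` has not yet been measured. It differs from compound 2 by hydrogen in place of acetyl on an oxygen on a saturated carbon, the same change as that from compound 1 to compound 3, made at the same place, in two pairs in all. Because the measured pair gave a 1.3-fold lower number from compound 1 to compound 3 (0.12 log units; within the scatter), the step from compound 2 to compound 4 is expected to be small as well, roughly a 1.3-fold lower number from compound 2 to compound 4 (0.12 log units; within the scatter), a shift that stays within the scatter. On that basis compound 4 is estimated at 38000 nM in this assay, with a range from 20000 nM to 75000 nM expected to cover most repeats.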

Compound 4, half-maximal cytotoxic concentration: 61400 nM
Compound 4: middle estimate off by 1.6-fold (0.21 log units), on the low side; measured number inside the range.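

In this assay, replacing the acetyl with hydrogen on the oxygen gives a 1.2-fold higher number from compound 2 to compound 4 (0.08 log units; within the scatter), so no direction can be read from this step. Set beside the earlier step, the change from acetoxymethyl to hydroxymethyl behaves alike on the two cores, and neither step can be told apart from no shift at all: the same change on two cores in this assay, a 1.3-fold lower number (0.12 log units; within the scatter) from compound 1 to compound 3 and a 1.2-fold higher number (0.08 log units; within the scatter) from compound 2 to compound 4, 1.6-fold (0.21 log units) apart, within the scatter of two such steps

Within the data shown here, this supports treating the acetyl as exchangeable with hydrogen at this place for this read-out on these two cores, but it rests on only two pairs and does not show a small real effect of either sign, nor that the same would hold on a third core or in another test.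

The compounds shown leave open whether a methyl ether, a longer acyl chain such as butanoyl, an amine or a carboxylic acid at this place would also stay within the scatter of the hydroxymethyl compounds. No pair shown isolates the difference between the core of compound 1 and the core of compound 2, so what that difference contributes on its own also remains open.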